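Chloro-to-methoxy swap on the core aryl of the triazole amide series

The source may hold more compounds than are shown below. What is called first, only, known or untested is meant among the compounds shown, and "the series" means these compounds.

Measured compounds:
compound 1 `O=C(NCc1cn(Cc2ccc(F)cc2)nn1)c1cn(-c2ccccc2)nc1-c1ccc(Cl)cc1` 570 nM
compound 2 `O=C(NCc1cn(Cc2ccc(Cl)cc2)nn1)c1cn(-c2ccccc2)nc1-c1ccc(Cl)cc1` 28800 nM
compound 3 `COc1ccc(Cn2cc(CNC(=O)c3cn(-c4ccccc4)nc3-c3ccc(Cl)cc3)nn2)cc1` 8000 nM

In a functional assay on MCF7 cells (Homo sapiens) for antiproliferative activity, read by sulforhodamine B assay, with a stated time of 48 h (a higher number here means a weaker inhibitor of growth, a lower number a stronger inhibitor of growth), compound 1 gives the lowest number of the three; both steps away from it, a 51-fold higher number from compound 1 to compound 2 (1.70 log units; beyond the scatter) and a 14-fold higher number from compound 1 to compound 3 (1.15 log units; beyond the scatter), are large. Compounds 2 and 3 share one core, compound 1 another; the cores differ by fluoro in place of chloro on an aromatic carbon. Between compounds 2 and 3 the change methoxy in place of chloro on an aromatic carbon gave a 3.6-fold lower number from compound 2 to compound 3 (0.56 log units; beyond the scatter), a modest step.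

Compound 4 `COc1ccc(-c2nn(-c3ccccc3)cc2C(=O)NCc2cn(Cc3ccc(F)cc3)nn2)cc1` is not yet measured. It differs from compound 1 by methoxy in place of chloro on an aromatic carbon, the same change, though cut one bond further out it reads only 4-chlorophenyl to 4-methoxyphenyl, not also the benzyl reading seen between compounds 2 and 3. The expectation for compound 4 rests on a 3.6-fold lower number from compound 2 to compound 3 (0.56 log units; beyond the scatter) alone; the step from compound 1 to compound 4 is expected at a 1.2-fold higher number from compound 1 to compound 4 (0.09 log units; within the scatter). Compound 4 is estimated at 700 nM, between 150 nM and 4000 nM.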

Compound 4, concentration for 50% growth inhibition: 460 nM
Compound 4: middle estimate off by 1.5-fold (0.18 log units), on the high side; measured number inside the range.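

On the core of compound 1, methoxy in place of chloro gives a 1.2-fold lower number from compound 1 to compound 4 (0.09 log units; within the scatter) in this assay, and this does not match the step seen on the other core: the same change on two cores in this assay, a 3.6-fold lower number (0.56 log units; beyond the scatter) from compound 2 to compound 3 and a 1.2-fold lower number (0.09 log units; within the scatter) from compound 1 to compound 4, 2.9-fold (0.46 log units) apart, beyond the scatter of two such steps. The size of this change therefore does not carry over unchanged from one core to the other in these compounds. Two pairs show only that mismatch, with no general rule and no cause for it.

Still open, going by these compounds, is how an amine or a carboxylic acid in place of chloro on the same aromatic carbon would read in this assay. Also open, on these data alone, is whether methoxy in place of chloro on any further core would follow either step.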